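Amidine series: substituent on the chain carbon, compound 4

This account rests on a few compounds, and the source may have more. Where it says the series, first, only, none or still open, it means among the compounds named here.

Measured so far in a physicochemical assay for acid dissociation:
compound 1 `Brc1cccc(Br)c1N(CC1CC1)C1=NCCN1`: 10.9
compound 2 `C#CCN(C1=NCCN1)c1c(Br)cccc1Br`: 10.1
compound 3 `Brc1cccc(Br)c1N(CC1CCCCC1)C1=NCCN1`: 11.2

Compound 1 stands second highest of the three numbers. Its nearest neighbour is compound 3, a number 0.30 log units higher from compound 1 to compound 3 (within the scatter), which is within the scatter. Its furthest is compound 2, a number 0.80 log units lower from compound 1 to compound 2 (beyond the scatter), beyond the scatter. The widest gap in the set is a number 1.10 log units higher from compound 2 to compound 3 (beyond the scatter).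

Compound 4 `Brc1cccc(Br)c1N(Cc1ccco1)C1=NCCN1` is not yet measured. It differs from compound 1 in one place: furan-2-yl in place of cyclopropyl on a saturated chain carbon bound to a nitrogen on an aromatic ring.

Both recorded steps bear on this change, as each replaces the same group on the saturated chain carbon bound to a nitrogen on an aromatic ring. The swap to a larger saturated ring, cyclohexyl in place of cyclopropyl, left the number within the scatter. The swap to ethynyl, an unsaturated group, lowered it by a modest amount. Furan-2-yl is an aromatic ring with one hetero atom and one hydrogen-bond acceptor, and is closer in kind to ethynyl than to cyclohexyl. Compound 4 is therefore expected to sit below compound 1, with a step of a number 0.50 log units lower from compound 1 to compound 4 (beyond the scatter) expected. For compound 4 the estimate is 10.4, with the range 9.9 to 10.9.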

Compound 4, acid dissociation constant: 10.5
The estimate for compound 4 lay 0.10 log units below the measured number; the measured number falls inside the stated range.
By their numbers in this assay, from the lowest: compound 2; then compound 4; then compounds 1 and 3 (each within the scatter of the next).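

In this assay, an aromatic ring on the saturated chain carbon bound to a nitrogen on an aromatic ring gives a level of its own, distinct from ethynyl (a number 0.40 log units higher from compound 2 to compound 4 (beyond the scatter)) and from cyclopropyl (a number 0.40 log units lower from compound 1 to compound 4 (beyond the scatter)). The earlier swap between saturated rings stayed within the scatter (a number 0.30 log units higher from compound 1 to compound 3 (within the scatter)), whereas furan-2-yl in place of cyclohexyl does not (a number 0.70 log units lower from compound 3 to compound 4 (beyond the scatter)), so a ring at this place does not by itself keep the number at the level of compounds 1 and 3. Across these four compounds, the two saturated rings read higher than the two unsaturated groups, with no compound going against this, and nothing measured here accounts for the steps.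

Open, from the compounds shown here alone, is whether the lower number of compound 4 goes with the ring oxygen or with the aromatic ring, a question that phenyl and tetrahydrofuran-2-yl at this place would separate. Also open, going by these compounds, is whether the same order of groups would hold with a change elsewhere on the shared core.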